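Aryl Substituent Pattern and Antiproliferative Potency in a Fused Pyranone Series

This account rests on a few compounds, and the source may have more. Where it says the series, first, only, none or still open, it means among the compounds named here.

Measured compounds:
Compound 1 `CCOc1ccc(-c2cc(=O)c3c(o2)C(CC)(CC)C(=O)C(CC)=C3O)cc1` — 7.54 uM
Compound 2 `CCC1=C(O)c2c(oc(-c3cccc(C)c3)cc2=O)C(CC)(CC)C1=O` — 3.69 uM
Compound 3 `CCC1=C(O)c2c(oc(-c3ccc(C)c(Cl)c3)cc2=O)C(CC)(CC)C1=O` — 2.15 uM

All three numbers come from a functional assay on KBVIN cells (Homo sapiens) for antiproliferative activity, read by sulforhodamine B assay, with a stated time of 3 days; on this read-out lower numbers stand for an effect already at smaller amounts and higher numbers for an effect only at larger amounts of compound. Compound 3 carries the lowest number of the three. Its nearest neighbour is compound 2, and the step between them, a 1.7-fold lower number from compound 2 to compound 3 (0.23 log units; within the scatter), does not allow the two to be ordered. Compound 1 is the furthest, as seen in a 3.5-fold lower number from compound 1 to compound 3 (0.54 log units; beyond the scatter), and the related step of a 2.0-fold lower number from compound 1 to compound 2 (0.31 log units; beyond the scatter) is likewise modest.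

Compound 4 `CCC1=C(O)c2c(oc(-c3cc(C)ccc3F)cc2=O)C(CC)(CC)C1=O` has not yet been measured. It differs from compound 3 in a single place: 2-fluoro-5-methylphenyl in place of 3-chloro-4-methylphenyl on an aromatic carbon. A methyl group and a halogen remain on the aryl ring, but the halogen is now fluorine and the substitution pattern is different. The step that bears most on this change is a 1.7-fold lower number from compound 2 to compound 3 (0.23 log units; within the scatter), which shows how little the aryl halogen altered the read-out; the two steps from compound 1 show that aryl replacement in this set has moved numbers only modestly.

Compound 4 is therefore expected to sit close to compound 3, with an estimated step of a 1.4-fold higher number from compound 3 to compound 4 (0.14 log units; within the scatter). In this assay compound 4 is expected to give about 3 uM, with a range from 1.2 uM to 7.5 uM.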

Compound 4, concentration for half-maximal effect: 3.24 uM
Beside the measured number, compound 4's estimate is 1.1-fold (0.03 log units) below it, and the stated range covers the measured number.
By their numbers in this assay, from the lowest: compounds 3, 4 and 2 (each within the scatter of the next); then compound 1.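

In this assay, 2-fluoro-5-methylphenyl in place of 3-chloro-4-methylphenyl gives a 1.5-fold higher number from compound 3 to compound 4 (0.18 log units; within the scatter) and so does not order the two, which shows that this position tolerates a change of both halogen and substitution pattern within the scatter. Fluoro in place of hydrogen on the aryl ring gives a 1.1-fold lower number from compound 2 to compound 4 (0.06 log units; within the scatter) and likewise leaves the two unordered, while 2-fluoro-5-methylphenyl in place of 4-ethoxyphenyl gives a 2.3-fold lower number from compound 1 to compound 4 (0.37 log units; beyond the scatter) as a modest step beyond the scatter, so that compound 4 also stands apart from compound 1. No measurement is available here that would account for any of these steps.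

Compound 3 and compound 4 differ in both the halogen and the substitution pattern, so the compounds shown cannot separate the contribution of one from that of the other. From the compounds shown here alone, it also remains open whether a carboxylic acid, an aminomethyl group or a longer alkoxy chain on this aryl ring would give a step clearly beyond the scatter, and whether replacing the ethyl groups on the shared core would matter more than any of the aryl changes seen so far.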